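The compounds below may be only part of what the source reports. "The series", "measured", "known", "first", "only" and "open" are said of these compounds alone.

Measured so far in a functional assay on BT-549 cells (Homo sapiens) for inhibition, read by sulforhodamine B assay, with a stated time of 6 days; on this read-out higher numbers stand for weaker inhibition and lower numbers for stronger inhibition:

compound 1 `CNCCNCc1cccc(-c2nc(NC3CCOCC3)c(C)c(-c3ccnc4[nH]ccc34)n2)c1` — 25200 nM
compound 2 `CNCCNCc1cccc(-c2nc(NC3CCOCC3)c(C)c(-c3cncnc3)n2)c1` — a limit, > 50000 nM
compound 3 `CNCCNCc1cccc(-c2nc(NC3CCOCC3)c(C)c(-c3cn(C)nc3C)n2)c1` — a limit, > 50000 nM
compound 4 `CNCCNCc1cccc(-c2nc(NC3CCOCC3)c(C)c(-c3ccncc3)n2)c1` — not yet measured

For the measured compounds named here, compound 1 holds the only number in the set; the other two entries are limits. In this assay compound 2 reaches only the limit > 50000 nM. Compound 3 likewise gives only the limit > 50000 nM. As far as these compounds go, the step of an at least 1.9-fold higher number from compound 1 to compound 2 (0.29 log units; that floor lies within the scatter) and the step of an at least 1.9-fold higher number from compound 1 to compound 3 (0.29 log units; that floor lies within the scatter) both run toward the limit (the limit of > 50000 nM in this assay, at which 2 of the 3 values shown sit), so each floor is within the scatter and the true size of either step is unknown. The pair of compounds 2 and 3 shows two limits and nothing more.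

Compound 4 changes compound 1 as follows: a group of 6 heavy atoms (5 carbon, 1 nitrogen; one six-membered aromatic ring with 1 hetero atom) in place of a group of 9 heavy atoms (7 carbon, 2 nitrogen; one five-membered aromatic ring with 1 hetero atom, one six-membered aromatic ring with 1 hetero atom), on an aromatic carbon. Both measured steps away from compound 1 replaced the same group by a smaller aromatic ring and ended at the limit, so a higher number is expected for compound 4, of about a 2.4-fold higher number from compound 1 to compound 4 (0.38 log units; beyond the scatter). Compound 4 is estimated at 60000 nM, within 25000 nM to 150000 nM, with a fair chance that this assay again reports only a limit.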

Compound 4, half-maximal inhibitory concentration: > 50000 nM
Compound 4 was reported as a limit; the forecaster's own chance of this, stated with the estimate: 60%; the middle value does not contradict the limit.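

In this assay compound 4 gives only a limit, > 50000 nM. As far as these compounds go, the result is an at least 1.9-fold higher number from compound 1 to compound 4 (0.29 log units; that floor lies within the scatter), so pyridin-4-yl, a single ring with no hydrogen-bond donor, gives only a floor for this change on the aromatic carbon, and the true size of the step remains unknown. Pyridin-4-yl thus joins pyrimidin-5-yl and 1,3-dimethyl-1H-pyrazol-4-yl at the same limit, leaving the two-ring group of compound 1 as the only one here with a number, while the steps among compounds 2, 3 and 4 cannot be read: the limit of > 50000 nM in this assay, at which 3 of the 4 values shown sit.

From the compounds shown here alone, whether the hydrogen-bond donor or the second ring of the group in compound 1 matters remains open. A pyridin-4-yl carrying an amine would separate the two, provided its value falls inside the measurable range.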